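Series notes: 1-methylazetidin-3-yl to 1-acetylazetidin-3-yl

The compounds below may be only part of what the source reports. "The series", "measured", "known", "first", "only" and "open" are said of these compounds alone.

Measured so far in an ADME assay on microsomes from liver (Mus musculus, strain CD-1) for metabolic stability, read by LC-MS, tested at 2 uM; on this read-out lower numbers stand for a shorter-lived compound and higher numbers for a longer-lived compound
- compound 1 `Cn1cc(CNC(=O)c2ccncc2Nc2cc(-c3ccc4ccn(C)c4c3)c3nccnc3c2)cn1` gives 0.267 h
- compound 2 `CN1CC(NC(=O)c2ccncc2Nc2cc(-c3ccc4ccn(C)c4c3)c3nccnc3c2)C1` gives > 1 h

Compound 2 stands at > 1 h as a limit of the assay and not as a number. Compound 3 `CC(=O)N1CC(NC(=O)c2ccncc2Nc2cc(-c3ccc4ccn(C)c4c3)c3nccnc3c2)C1` carries acetyl in place of methyl on an amine nitrogen in a ring and is otherwise unchanged. Among the measured compounds shown here, the only measured step that bears on this is an at least 3.7-fold higher number from compound 1 to compound 2 (0.57 log units; beyond the scatter) and it lies beyond the scatter. That step exchanges the whole group on the amide-type nitrogen, so it gives no direct size for this change. No step beyond the scatter is therefore expected in this assay in either direction. The estimate means a number no higher from compound 2 to compound 3 (the limit leaves the size open) as the expected step. For compound 3 the expected half-life is 1 h with an estimated range from 0.4 h to 2.5 h for now.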

Compound 3, half-life: 0.817 h
For compound 3 the middle estimate is 1.2-fold (0.09 log units) above the measured one; low and high end bracket the measured number.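

In this assay, 1-acetylazetidin-3-yl on the amide-type nitrogen gives a clear gain over (1-methyl-1H-pyrazol-4-yl)methyl, with a 3.1-fold higher number from compound 1 to compound 3 (0.49 log units; beyond the scatter). Acetyl in place of methyl on the amine nitrogen in the ring reads as an at least 1.2-fold lower number from compound 2 to compound 3 (0.08 log units; that floor lies within the scatter), which neither shows nor excludes a step beyond the scatter. The true size of that step stays open because the value of compound 2 is a limit of the assay and not a number: the limit of > 1 h in this assay, at which 1 of the 3 values shown sits.

As far as these compounds go, how a free ring amine, a methanesulfonyl group or a longer acyl chain on this nitrogen would read in this assay remains open. From the compounds shown here alone, whether acetyl in place of methyl behaves the same way on a different core also stays open.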